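This account rests on a few compounds, and the source may have more. Where it says the series, first, only, none or still open, it means among the compounds named here.

Measured so far:
- Compound 1, `Cc1cc(N2CC[C@@H](C)[C@@H](N(C)c3ncnc4[nH]ccc34)C2)n2nc(SCC3CC3)nc2n1`, gives 9540 nM in a functional assay on MGC-803 cells (Homo sapiens) for inhibition, read by MTT assay, with a stated time of 72 h; on this read-out higher numbers stand for weaker inhibition and lower numbers for stronger inhibition
- Compound 2, `COc1ccc(CSc2nc3nc(C)cc(N4CC[C@@H](C)[C@@H](N(C)c5ncnc6[nH]ccc56)C4)n3n2)cc1`, gives 15200 nM
- Compound 3, `CCCSc1nc2nc(C)cc(N3CC[C@@H](C)[C@@H](N(C)c4ncnc5[nH]ccc45)C3)n2n1`, gives 15500 nM

Compound 1 holds the lowest of the three numbers, but its nearest neighbour is compound 2 with a 1.6-fold higher number from compound 1 to compound 2 (0.20 log units; within the scatter) and its furthest is compound 3 with a 1.6-fold higher number from compound 1 to compound 3 (0.21 log units; within the scatter), so all three compounds sit together within the scatter and none can be called stronger than another. Compound 4, `Cc1cc(N2CC[C@@H](C)[C@@H](N(C)c3ncnc4[nH]ccc34)C2)n2nc(SCc3ccc([N+](=O)[O-])cc3)nc2n1`, has not yet been measured. Its difference from compound 1 is 4-nitrophenyl in place of cyclopropyl on a saturated chain carbon bound to a sulfur. For the measured compounds named here, the step that bears most closely on this is the one to compound 2, where a 4-methoxyphenyl entered at the same place and gave a 1.6-fold higher number from compound 1 to compound 2 (0.20 log units; within the scatter); the step to compound 3, a 1.6-fold higher number from compound 1 to compound 3 (0.21 log units; within the scatter), and the one between them, a 1.0-fold higher number from compound 2 to compound 3 (0.01 log units; within the scatter), show that this position has so far tolerated very different groups without moving the number beyond the scatter. A similar outcome is therefore expected for compound 4, with an estimated step of a 1.4-fold higher number from compound 1 to compound 4 (0.13 log units; within the scatter). Compound 4 is estimated at 13000 nM, within a range of 5000 nM to 35000 nM.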

Compound 4, half-maximal inhibitory concentration: 27000 nM
Beside the measured number, compound 4's estimate is 2.1-fold (0.32 log units) below it, and the stated range covers the measured number.
By their numbers in this assay, from the lowest: compounds 1, 2, 3 and 4 (each within the scatter of the next, the first and the last beyond it).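

In this assay, this position now shows its first step beyond the scatter: 4-nitrophenyl in place of cyclopropyl gives a 2.8-fold higher number from compound 1 to compound 4 (0.45 log units; beyond the scatter), a modest change. Compound 4 still does not separate from the two compounds with other groups at this place, with ethyl replaced by 4-nitrophenyl giving a 1.7-fold higher number from compound 3 to compound 4 (0.24 log units; within the scatter) and nitro in place of methoxy on an aromatic carbon giving a 1.8-fold higher number from compound 2 to compound 4 (0.25 log units; within the scatter). Nothing measured here accounts for the higher number of compound 4 compared with compound 1.

A plain phenyl at this place, carrying neither nitro nor methoxy, could show whether it stays with compound 1 or moves toward compound 4. Going by these compounds, it also remains open whether an amine or a carboxylic acid on the aromatic ring would give a number lower than that of compound 1.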